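Cytotoxicity of Three Quinoline Amides: From Chlorine to Bromine

A few compounds are considered here, and "the series" means these few. Any claim that something is new, unique, unknown or untested is made for them only; others in the source may bear on it.

Three close relatives are considered here, each built on the same core and differing only in the aryl group carried on the amide-type nitrogen. Compound 1 `O=C(Nc1cccc(F)c1)c1ccc2cccc(O)c2n1` carries a 3-fluorophenyl there. In an ADME assay on THP-1 cells (Homo sapiens) for cytotoxicity, read by WST assay, with a stated time of 24 h (on this read-out higher numbers stand for weaker inhibition and lower numbers for stronger inhibition), compound 1 gives > 30000 nM, which is a limit of the assay and not a number. Compound 2 `O=C(Nc1ccc(Cl)cc1)c1ccc2cccc(O)c2n1` carries a 4-chlorophenyl instead. In this assay compound 2 gives > 30000 nM, again a limit rather than a number. The step that the two limits leave unreadable from compound 1 to compound 2 therefore cannot be sized, since both ends sit at the limit of > 30000 nM in this assay, at which 2 of the 2 values shown sit, and compound 2 stands only as a limit on the numbers shown.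

Compound 3 `O=C(Nc1cccc(Br)c1)c1ccc2cccc(O)c2n1` is the next member, not yet measured. It differs from compound 2 by 3-bromophenyl in place of 4-chlorophenyl on an amide-type nitrogen. The only measured step bears on this change without giving it a size, and no shown value places any of these compounds below the limit. Compound 3 is therefore expected to give an estimated 40000 nM, with a range from 15000 nM to 100000 nM. The estimated step that the limit leaves unreadable from compound 2 to compound 3 is expected to be none beyond the scatter.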

Compound 3, half-maximal inhibitory concentration: > 30000 nM
Compound 3 gave a limit, no number; the forecaster's own chance of this, stated with the estimate: 85%; the middle value does not contradict the limit.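

In this assay compound 3 gives > 30000 nM, which is a limit and not a number. Within the data shown here, no step among compound 1, compound 2 and compound 3 can be read, because each stands only as a limit: the limit of > 30000 nM in this assay, at which 3 of the 3 values shown sit. The compounds shown leave open whether any aryl group on the amide-type nitrogen would give a readable number.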